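A Chloro Swap on a Weakly Active Acid

A few compounds are considered here, and "the series" means these few. Any claim that something is new, unique, unknown or untested is made for them only; others in the source may bear on it.

Measured so far in a functional assay on MCF7 cells (Homo sapiens) for cytotoxicity, read by MTT assay, with a stated time of 72 h; on this read-out lower numbers stand for stronger inhibition and higher numbers for weaker inhibition:
Compound 1 (`Cc1oc2ncnc(Nc3cccc(Cl)c3)c2c1C(=O)NCCO`) > 1000000 nM (a limit of the assay)
Compound 2 (`Cc1oc2ncnc(Nc3ccccc3)c2c1C(=O)O`) 246000 nM

Compound 1 gives > 1000000 nM, which is a limit of the assay and not a number. Among the measured compounds shown here, compound 2 with 246000 nM is therefore the only true number so far, and there is no second number to rank it against.

Compound 3 (`Cc1oc2ncnc(Nc3cccc(Cl)c3)c2c1C(=O)O`) has not yet been measured. It is compound 2 with one change (chloro in place of hydrogen on an aromatic carbon): chloro in place of hydrogen on an aromatic carbon, so that phenyl becomes 3-chlorophenyl.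

For the measured compounds named here, no measured pair shows what this exchange does in this assay, so the expectation is cautious. The expected change (a 1.6-fold lower number from compound 2 to compound 3 (0.21 log units; within the scatter)) is small, leaning toward somewhat stronger inhibition, and it may not rise beyond the usual scatter of repeats. Going by the values given here, the estimate stays close because compound 2 with 246000 nM is the only number to lean on. In this assay compound 3 is estimated at 150000 nM with an expected range from 50000 nM to 450000 nM for repeat measurements.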

Compound 3, half-maximal inhibitory concentration: 57500 nM
Compound 3: the middle estimate sits 2.6-fold (0.42 log units) above what was measured, and the stated range covers the measured number.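

In this assay, chloro in place of hydrogen on an aromatic carbon, turning phenyl into 3-chlorophenyl, gives a 4.3-fold lower number from compound 2 to compound 3 (0.63 log units; beyond the scatter), the first measured sign that this position responds to a change. With 3-chlorophenyl held constant, hydroxy in place of (2-hydroxyethyl)amino on a carbonyl carbon gives an at least 17-fold lower number from compound 1 to compound 3 (1.24 log units; beyond the scatter), so the group on the carbonyl carbon also matters in this series, and this step is larger than the chloro step. Compound 1 gives a limit of the assay and not a number, so the second step has a floor for its size but no exact value: the limit of > 1000000 nM in this assay, at which 1 of the 3 values shown sits.

As far as these compounds go, it remains open whether chloro is special here or whether fluoro, methyl or methoxy on the same aromatic carbon would do as much, and whether chloro would have the same effect on a different carbon of that ring. From the compounds shown here alone, it is also open how far the carbonyl group can be varied, since a methyl ester or a plain primary amide would show whether the step from compound 1 to compound 3 depends on hydroxy itself or on losing (2-hydroxyethyl)amino.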